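A few compounds are considered here, and "the series" means these few. Any claim that something is new, unique, unknown or untested is made for them only; others in the source may bear on it.

Series notes. Compound 1 `CC[C@]1(C(=O)O)CC[C@H](C(=O)N2CC[C@](c3ccc(C(F)(C(F)(F)F)C(F)(F)F)cc3)(S(=O)(=O)c3ccc(F)cc3)C2)CC1` has in an ADME assay on microsomes from liver (Mus musculus) for metabolic stability, with a stated time of 10 min (a higher number here means that more of the compound is left, a lower number that less of the compound is left), the entry "not determined" (no result reported), and compound 2 `O=C(O)C12CCC(C(=O)N3CC[C@](c4ccc(C(F)(C(F)(F)F)C(F)(F)F)cc4)(S(=O)(=O)c4ccc(F)cc4)C3)(CC1)C2` has in this assay the entry "not determined" (no result reported); for both no result was reported, so compound 2 stands without a number, alongside one further entry that also has none. Going by the values given here, the only measured member is compound 3 `O=C([C@H]1CC[C@H](CO)CC1)N1CC[C@](c2ccc(C(F)(C(F)(F)F)C(F)(F)F)cc2)(S(=O)(=O)c2ccc(F)cc2)C1`, which in this assay gives 63%. The next compound, compound 4 `O=C(N1CC[C@](c2ccc(C(F)(C(F)(F)F)C(F)(F)F)cc2)(S(=O)(=O)c2ccc(F)cc2)C1)C1(F)CCS(=O)(=O)CC1`, is to be measured in this assay. Relative to compound 2 it carries a group of 9 heavy atoms (5 carbon, 2 oxygen, 1 fluorine, 1 sulfur; one six-membered non-aromatic ring with 1 hetero atom) in place of a group of 10 heavy atoms (8 carbon, 2 oxygen; 2 five-membered non-aromatic rings of carbon only), on a carbonyl carbon. Among the compounds with values here, no step between measured compounds exists, and the lone number of compound 3, 63%, is the only anchor in this assay. The step to compound 4 is expected to be modest, in either direction, not clearly beyond the scatter. Compound 4 is expected in this assay to give around 68%, estimated between 45% and 90%.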

Compound 4, percent of the compound remaining: 90%
The estimate for compound 4 lay 22 percentage points below the measured number; the measured number falls inside the stated range.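

At this carbonyl carbon, the place changes the read-out in this assay: 4-fluoro-1,1-dioxothian-4-yl in place of 4-(hydroxymethyl)cyclohexyl gives a number 27 percentage points higher from compound 3 to compound 4 (beyond the scatter). Going by these compounds alone, this is the first readable step; steps involving compound 1 or compound 2 cannot be read. Nothing available accounts for the rise.

On these data alone, the whole group changes in this one step, so the separate shares of the fluorine and the ring sulfur stay open. Also open, as far as these compounds go, is how a 1,1-dioxothian-4-yl group without fluorine, or a group carrying an amine, would read on this carbonyl carbon.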